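The compounds below may be only part of what the source reports. "The series", "measured", "known", "first", "only" and "open" are said of these compounds alone.

In a physicochemical assay for solubility, read by nephelometry, measured as kinetic solubility, at pH 2.0 (on this read-out lower numbers stand for lower solubility and higher numbers for higher solubility), compound 2, `CC(C)(C)c1cc(C(=O)Nc2cccc(CN)c2)n(Cc2ccccc2)n1`, gives > 100 ug/mL, which is a limit of the assay rather than a number. Compound 3, `NCc1csc(NC(=O)c2cc3ccccc3o2)n1`, likewise reaches a limit, at > 100 ug/mL. Compound 1, `NCc1csc(NC(=O)c2ccon2)n1`, gives 50 ug/mL. Two of the three values therefore sit at the limit of > 100 ug/mL in this assay, at which 2 of the 3 values shown sit. Compound 4, `CNCc1csc(NC(=O)c2cc(C(C)(C)C)nn2Cc2ccccc2)n1`, has not yet been measured; it differs from compound 2 by 4-((methylamino)methyl)-1,3-thiazol-2-yl in place of 3-(aminomethyl)phenyl on an amide-type nitrogen. Going by the values given here, no measured pair shows this exact change, so only the three values above guide the expectation. The step of a number no higher from compound 2 to compound 4 (the limit leaves the size open) is expected to be small, in no direction beyond the usual scatter, with a fair chance that the assay again reports only a limit. Compound 4 is estimated at 100 ug/mL, within a range from 40 ug/mL to 200 ug/mL.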

Compound 4, solubility: 25 ug/mL
The estimate for compound 4 lay 4.0-fold (0.60 log units) above the measured number, outside the stated range (below it).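

In this assay, 4-((methylamino)methyl)-1,3-thiazol-2-yl in place of 3-(aminomethyl)phenyl on an amide-type nitrogen gives an at least 4.0-fold lower number from compound 2 to compound 4 (0.60 log units; beyond the scatter). So the group at this place can move the read-out beyond the scatter, which no earlier comparison could show. Compound 2 gives > 100 ug/mL, a limit of the assay and not a number, so the full size of the step stays open: the limit of > 100 ug/mL in this assay, at which 2 of the 4 values shown sit.

The change alters the ring and the amine together, and the compounds shown cannot separate the two. A 3-((methylamino)methyl)phenyl group at this place would be needed to tell them apart.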